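A few compounds are considered here, and "the series" means these few. Any claim that something is new, unique, unknown or untested is made for them only; others in the source may bear on it.

Compound 1 `c1ccc(-c2nn(-c3ccccc3)cc2-c2nc3ccccc3[nH]2)cc1` gives 1550 nM in a functional assay on HeLa cells (Homo sapiens) for antiproliferative activity, read by MTT assay, with a stated time of 48 h; on this read-out higher numbers stand for weaker inhibition and lower numbers for stronger inhibition. Compound 2 `Cc1ccc2[nH]c(-c3cn(-c4ccccc4)nc3-c3ccccc3)nc2c1` carries the change methyl in place of hydrogen on an aromatic carbon on the core of compound 1; in this assay compound 2 gives 6560 nM, the step being a 4.2-fold higher number from compound 1 to compound 2 (0.63 log units; beyond the scatter). Compound 3 `Cc1ccc2[nH]c(-c3cn(-c4ccccc4)nc3-c3ccc(Cl)cc3)nc2c1` has chloro in place of hydrogen on an aromatic carbon; in this assay compound 3 gives 5360 nM, the step being a 1.2-fold lower number from compound 2 to compound 3 (0.09 log units; within the scatter). The difference between the cores of compound 1 and compound 3 is not broken down here. Compound 4 `Cc1cc2nc(-c3cn(-c4ccccc4)nc3-c3ccc(Cl)cc3)[nH]c2cc1C` takes the change methyl in place of hydrogen on an aromatic carbon from compound 3. Its place differs from the earlier one in being ortho to a methyl group (1 heavy atom), so this is the same kind of change, not the same change. The expected step is a 1.7-fold higher number from compound 3 to compound 4 (0.23 log units; within the scatter), set beside a 4.2-fold higher number from compound 1 to compound 2 (0.63 log units; beyond the scatter) and resting on it with reduced weight since the place is not identical. In this assay compound 4 is expected to give 9000 nM, likely between 3500 nM and 22000 nM.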

Compound 4, half-maximal inhibitory concentration: 21800 nM
The estimate for compound 4 lay 2.4-fold (0.38 log units) below the measured number; low and high end bracket the measured number.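

In this assay, methyl in place of hydrogen on an aromatic carbon again gives a weaker result, with a 4.1-fold higher number from compound 3 to compound 4 (0.61 log units; beyond the scatter), and this matches the earlier step: the same change on two cores in this assay, a 4.2-fold higher number (0.63 log units; beyond the scatter) from compound 1 to compound 2 and a 4.1-fold higher number (0.61 log units; beyond the scatter) from compound 3 to compound 4, 1.0-fold (0.02 log units) apart, within the scatter of two such steps. The change therefore carries over in size between these two pairs, although its place in compound 4 is ortho to a methyl group. This rests on two pairs in one cell assay, so it shows neither that the step would hold on other cores nor why methyl has this effect.

As far as these compounds go, it remains open whether an amine, a carboxylic acid or a longer chain on the same ring would give a step of similar size. From the compounds shown here alone, whether such a group would move the number in the same direction also remains open.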